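Fluoro in place of pentyloxy on the shared core

A few compounds are considered here, and "the series" means these few. Any claim that something is new, unique, unknown or untested is made for them only; others in the source may bear on it.

Compound 2 (`CCCCCOc1ccc2oc(/C=C/[S+](C)[O-])cc(=O)c2c1`) gives 6600 nM in a functional assay on DLD-1 cells (Homo sapiens) for cytotoxicity, with a stated time of 48 h (on this read-out lower numbers stand for stronger inhibition and higher numbers for weaker inhibition), and sits within the scatter of the other two measured values. Compound 1 (`Cc1ccc2c(=O)cc(/C=C/[S+](C)[O-])oc2c1`) gives 7000 nM in this read-out, and compound 3 (`Cc1cccc2oc(/C=C/[S+](C)[O-])cc(=O)c12`) gives 5500 nM here. Compound 4 (`C[S+]([O-])/C=C/c1cc(=O)c2cc(F)ccc2o1`) has not yet been measured. It carries fluoro in place of pentyloxy on an aromatic carbon. For the measured compounds named here, no measured pair isolates a single change, so the data give no direction for this one. No change beyond the scatter is expected in this assay for this swap. The expected step is a 1.1-fold lower number from compound 2 to compound 4 (0.04 log units; within the scatter) on this estimate. For compound 4 the estimated value is 6000 nM with an expected range from 2500 nM to 14000 nM for this measurement.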

Compound 4, half-maximal inhibitory concentration: 7000 nM
The estimate for compound 4 lay 1.2-fold (0.07 log units) below the measured number; the measured number falls inside the stated range.
By their numbers in this assay, from the lowest: compounds 3, 2, 1 and 4 (each within the scatter of the next).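

In this assay, for the compounds shown here, the swap of pentyloxy for fluoro on this aromatic carbon gives a 1.1-fold higher number from compound 2 to compound 4 (0.03 log units; within the scatter), the first step that isolates a single change. At this position, the read-out therefore does not separate the pentyloxy chain from the much smaller fluoro. No further data bear on why the two groups read alike.

As far as these compounds go, whether an amine or a carboxylic acid on this aromatic carbon would also leave the read-out unmoved remains open. So does whether the same swap elsewhere on the shared core would behave alike.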